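The source may hold more compounds than are shown below. What is called first, only, known or untested is meant among the compounds shown, and "the series" means these compounds.

Of the compounds shown here, three built on one shared core have been tested in an in vitro functional assay on RBL cells for antagonist activity at C-C chemokine receptor type 8 (Homo sapiens), read by FLIPR and calcium flux; on this read-out higher numbers stand for weaker inhibition and lower numbers for stronger inhibition. Compound 1 `COc1ccc2nccc(C3CN(C4CCN(Cc5cc6ccccc6[nH]5)CC4)C(=O)O3)c2c1` gives 25.1 nM. Compound 2 `COc1ccc2nccc(C3CN(C4CCN(Cc5cc6ccccc6n5C)CC4)C(=O)O3)c2c1` gives 3160 nM, and the step of a 130-fold higher number from compound 1 to compound 2 (2.10 log units; beyond the scatter) shows how much the methyl in place of hydrogen on the aromatic nitrogen weakens inhibition. Compound 3 `COc1ccc2nccc(C3CN(C4CCN(Cc5c[nH]c6ccccc56)CC4)C(=O)O3)c2c1` is reported in this assay only as a limit, < 50200 nM, so compound 3 stands on no number of its own (the limit of < 50200 nM in this assay, at which 1 of the 3 values shown sits). For that reason a step that the limit leaves unreadable from compound 1 to compound 3 and a step that the limit leaves unreadable from compound 2 to compound 3 cannot be sized.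

Compound 4 `COc1ccc2nccc(C3CN(C4CCN(Cc5cc6ccccc6o5)CC4)C(=O)O3)c2c1` differs from compound 3 in one place: 1-benzofuran-2-yl in place of 1H-indol-3-yl on a saturated chain carbon bound to an amine nitrogen in a ring. Among the compounds with values here, no measured step covers this exact change. The nearest guide is the pair of compound 1 and compound 2, where the bicyclic group of compound 1 keeps its hydrogen-bond donor and compound 2 does not; compound 4, carrying a 1-benzofuran-2-yl, also has no donor. Compound 4 is therefore expected to land nearer compound 2, at an estimated 2000 nM, within 300 nM to 15000 nM. Against the limit of compound 3, that estimate means a step that the limit leaves unreadable from compound 3 to compound 4.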

Compound 4, half-maximal inhibitory concentration: 1260 nM
The estimate for compound 4 lay 1.6-fold (0.20 log units) above the measured number; the measured number falls inside the stated range.
By their numbers in this assay, from the lowest: compound 1; then compound 4; then compound 2.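

With 1-benzofuran-2-yl in place of 1H-indol-2-yl there is a 50-fold higher number from compound 1 to compound 4 (1.70 log units; beyond the scatter), so a second change that removes the hydrogen-bond donor from this place, now with an oxygen in the ring rather than a methyl on the nitrogen, also gives a large step. With 1-benzofuran-2-yl in place of 1-methyl-1H-indol-2-yl there is a 2.5-fold lower number from compound 2 to compound 4 (0.40 log units; beyond the scatter), a modest step beyond the scatter, which leaves both compounds without the donor far from compound 1. Compound 3 has only a limit and no number, so no step to or from it can be read: the limit of < 50200 nM in this assay, at which 1 of the 4 values shown sits.

The compounds shown therefore cannot say whether the donor alone sets the number, since compound 3 also carries one. On these data alone, it also remains open how 1H-benzimidazol-2-yl or 1-benzothiophen-2-yl would fare in this place.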